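Extending the Basic Side Chain of a Urea Quinazoline

The source may report more compounds than this note shows. Statements on the series, on what has been measured and on what is new or still open speak of the compounds shown alone.

Compound 1 `CN(C)CCNC(=O)Nc1cc2c(Nc3ccc(F)c(Cl)c3)ncnc2cc1O[C@H]1CCOC1` gives 806 nM in a functional assay on A-431 cells (Homo sapiens) for antiproliferative activity, read by sulforhodamine B assay, with a stated time of 72 h (a lower number here means a stronger inhibitor, a higher number a weaker inhibitor), the lower of the two numbers recorded so far. Going by the values given here, its only measured neighbour, compound 2 `COCCCNC(=O)Nc1cc2c(Nc3ccc(F)c(Cl)c3)ncnc2cc1O[C@H]1CCOC1`, gives 4100 nM in this assay, a change of a 5.1-fold higher number from compound 1 to compound 2 (0.71 log units; beyond the scatter). Compound 3 `CN(C)CCCNC(=O)Nc1cc2c(Nc3ccc(F)c(Cl)c3)ncnc2cc1O[C@H]1CCOC1` differs from compound 1 by (dimethylamino)methyl in place of dimethylamino on a saturated chain carbon, two bonds along the chain from an amide-type nitrogen. Among the compounds with values here, no measured step follows this same change; the step from compound 1 to compound 2 replaces the dimethylamino group rather than lengthening the chain that carries it, so it bears on compound 3 only in showing that the dimethylamino group itself goes with the lower number in this assay. With the group kept and the chain lengthened by one carbon, the step is expected to stay within the scatter, so compound 3 is estimated at a 1.1-fold higher number from compound 1 to compound 3 (0.05 log units; within the scatter). Compound 3 is therefore expected to give 900 nM in this assay, within a range from 400 nM to 2000 nM.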

Compound 3, half-maximal inhibitory concentration: 226 nM
Compound 3: the middle estimate sits 4.0-fold (0.60 log units) above what was measured; the measured number lies below the stated range.
By their numbers in this assay, from the lowest: compound 3; then compound 1; then compound 2.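

Lengthening the chain in this assay is not neutral at this position: the change from 2-(dimethylamino)ethyl to 3-(dimethylamino)propyl gives a 3.6-fold lower number from compound 1 to compound 3 (0.55 log units; beyond the scatter) and so moves the number beyond the scatter, which shows that chain length counts here as well as the dimethylamino group. With the chain held the same, dimethylamino in place of methoxy gives an 18-fold lower number from compound 2 to compound 3 (1.26 log units; beyond the scatter) and is the largest step among these compounds, a cleaner comparison of the two end groups than the earlier pair allowed. No measurement offered here explains either step.

As far as these compounds go, whether a longer chain, such as 4-(dimethylamino)butyl, would lower the number further or reverse the step remains open. From the compounds shown here alone, it is also open whether a different end group on the propyl chain, such as a primary amine or diethylamino, would match compound 3 in this assay.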